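Swapping Chloro for Methyl in Compound 3

The source may report more compounds than this note shows. Statements on the series, on what has been measured and on what is new or still open speak of the compounds shown alone.

In a functional assay on DU-145 cells (Homo sapiens) for inhibition, read by trypan blue exclusion, with a stated time of 72 h (a lower number here means a stronger inhibitor, a higher number a weaker inhibitor), compound 1 (`COc1ccc(Nc2ncc3cc(S(=O)(=O)c4ccc(C)cc4)c(=O)n(C)c3n2)cc1`) gives 100000 nM, compound 2 (`Cc1ccc(S(=O)(=O)c2cc3cnc(Nc4cnc5c(c4)CC(=O)N5)nc3n(C)c2=O)cc1`) gives 15000 nM and compound 3 (`Cn1c(=O)c(S(=O)(=O)c2ccc(Cl)cc2)cc2cnc(Nc3cccc4[nH]ccc34)nc21`) gives 5000 nM, the lowest of the three numbers and so the strongest inhibitor among them. Compound 4 (`Cc1ccc(S(=O)(=O)c2cc3cnc(Nc4cccc5[nH]ccc45)nc3n(C)c2=O)cc1`) is compound 3 with one small exchange: methyl in place of chloro on an aromatic carbon, para to a large group (methyl in place of chloro on an aromatic carbon). Among the compounds with values here, the only measured step between compounds that differ in one place is a 6.7-fold lower number from compound 1 to compound 2 (0.82 log units; beyond the scatter). It is modest but beyond the scatter, and it concerns a different part of the molecule, since both of its compounds carry the 4-methylphenyl group. Within the data shown here, no measured pair therefore isolates this exchange, and there is no evidence for a shift in either direction. The expected outcome is no change at the digits printed from compound 3 to compound 4 (within the scatter), which means no step beyond the scatter. For compound 4 the estimated value is 5000 nM, with an expected range from 1500 nM to 17000 nM.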

Compound 4, half-maximal inhibitory concentration: 10000 nM
For compound 4 the middle estimate is 2.0-fold (0.30 log units) below the measured one; the range from low to high includes it.
By their numbers in this assay, from the lowest: compounds 3, 4 and 2 (each within the scatter of the next, the first and the last beyond it); then compound 1.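

Exchanging chloro for methyl gives, in this assay, a 2.0-fold higher number from compound 3 to compound 4 (0.30 log units; within the scatter), so this first direct look at the group on the sulfonyl-bearing phenyl ring does not separate 4-chlorophenyl from 4-methylphenyl. On the nitrogen on an aromatic ring, the step from 4-methoxyphenyl to 1H-indol-4-yl gives a 10-fold lower number from compound 1 to compound 4 (1.00 log units; beyond the scatter), while the other exchange at that place gives a 1.5-fold lower number from compound 2 to compound 4 (0.18 log units; within the scatter), so the 1H-indol-4-yl group and the group in compound 2 cannot be told apart here. Nothing measured alongside these numbers speaks to what lies behind them.

Going by these compounds, only chloro and methyl have been compared at this position, so it remains open whether an amine or a carboxylic acid there would shift the number beyond the scatter. Within the data shown here, the exchange has also been seen only with the 1H-indol-4-yl group, and it may not read the same with other groups on that nitrogen.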